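Swapping the Chain End of Compound 3

This account rests on a few compounds, and the source may have more. Where it says the series, first, only, none or still open, it means among the compounds named here.

Three carboxylic acids share one core and differ in the length of the chain carrying the acid: compound 1 `O=C(O)CCCCCCn1nc(-c2ccccc2)c(-c2ccccc2)c1-c1ccccc1`, compound 2 `O=C(O)CCCCCCCn1nc(-c2ccccc2)c(-c2ccccc2)c1-c1ccccc1` and compound 3 `O=C(O)CCCCCCCCCn1nc(-c2ccccc2)c(-c2ccccc2)c1-c1ccccc1`. In a functional assay for inhibition, with Homo sapiens as the target (a higher number here means a weaker inhibitor, a lower number a stronger inhibitor), compound 1 gives 22400 nM, compound 2 gives 3400 nM and compound 3 gives 5500 nM. Compound 3 therefore stands level with compound 2, within the scatter, and both sit beyond the scatter from compound 1. The measured steps are a 6.6-fold lower number from compound 1 to compound 2 (0.82 log units; beyond the scatter) and a 4.1-fold lower number from compound 1 to compound 3 (0.61 log units; beyond the scatter), both modest, while a 1.6-fold higher number from compound 2 to compound 3 (0.21 log units; within the scatter) stays within the scatter.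

The unmeasured compound 4 `O=C(O)COCCCCCCn1nc(-c2ccccc2)c(-c2ccccc2)c1-c1ccccc1` puts carboxymethoxy in place of 3-carboxypropyl on a saturated chain carbon, six bonds along the chain from an aromatic nitrogen. For the measured compounds named here, no measured compound carries carboxymethoxy, so the data cannot show what this swap does by itself. However, the chain of compound 4 is longer than that of compound 2 and shorter than that of compound 3, and a 1.6-fold higher number from compound 2 to compound 3 (0.21 log units; within the scatter) suggests little sensitivity to length in this range. The expected change is small, a 1.2-fold lower number from compound 3 to compound 4 (0.09 log units; within the scatter), which lies within the scatter. For compound 4 the estimated value in this assay is 4500 nM, with an expected range from 1500 nM to 13000 nM.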

Compound 4, half-maximal inhibitory concentration: 440 nM
For compound 4 the middle estimate is 10-fold (1.01 log units) above the measured one, outside the stated range (below it).
By their numbers in this assay, from the lowest: compound 4; then compounds 2 and 3 (each within the scatter of the next); then compound 1.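

In this assay, for the compounds shown here, the lengthened all-carbon chains of the earlier compounds shifted the number only modestly, whereas carboxymethoxy in place of 3-carboxypropyl, on a saturated chain carbon six bonds along the chain from an aromatic nitrogen, gives a 13-fold lower number from compound 3 to compound 4 (1.10 log units; beyond the scatter), a large step. The same end group also stands clear of the other two chains, with a 7.7-fold lower number from compound 2 to compound 4 (0.89 log units; beyond the scatter) and a 51-fold lower number from compound 1 to compound 4 (1.71 log units; beyond the scatter), so compound 4 is the strongest inhibitor of the four. This position therefore responds to what the chain end is made of, not only to its length, although no information is available on why the swap has so large an effect.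

Compound 4 differs from compound 3 in both the oxygen of the carboxymethoxy group and the number of heavy atoms in the group, so these two changes cannot be separated here. On these data alone, it also remains open how a thioether sulfur or an amine nitrogen in place of that oxygen would read, and whether a longer chain ending in carboxymethoxy would keep the lower number.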